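Halogen swap on the pendant aryl ring, cytotoxicity series

This account rests on a few compounds, and the source may have more. Where it says the series, first, only, none or still open, it means among the compounds named here.

Compound 1 `Cn1ccc2c(Oc3ccc(NC(=O)c4cc5cccnc5n(-c5ccc(Cl)cc5)c4=O)cc3)ncnc21` and compound 2 `Cn1ccc2c(Oc3ccc(NC(=O)c4cc5cccnc5n(-c5ccc(Br)cc5)c4=O)cc3)ncnc21` share one core and differ only in the change (bromo in place of chloro on an aromatic carbon). In a functional assay on HeLa cells (Homo sapiens) for cytotoxicity, read by MTT assay, with a stated time of 72 h (on this read-out lower numbers stand for stronger inhibition and higher numbers for weaker inhibition), compound 1 gives 49900 nM, and compound 2 gives 43800 nM; the step is a 1.1-fold lower number from compound 1 to compound 2 (0.06 log units; within the scatter). Compound 3 `O=C(Nc1ccc(Oc2ncnc3[nH]ccc23)c(F)c1)c1cc2cccnc2n(-c2ccc(Cl)cc2)c1=O` carries a different core, and the difference between the two cores is not broken down here. In this assay compound 3 gives 23900 nM. Compound 4 `O=C(Nc1ccc(Oc2ncnc3[nH]ccc23)c(F)c1)c1cc2cccnc2n(-c2ccc(Br)cc2)c1=O` stands to compound 3 as compound 2 stands to compound 1: the change is bromo in place of chloro on an aromatic carbon, the same change at the same place, a six-membered aromatic ring of carbon only, para to a large group. Among the compounds with values here, the one measured instance of this change, a 1.1-fold lower number from compound 1 to compound 2 (0.06 log units; within the scatter), stayed within the scatter, so the expected step in this assay is a 1.1-fold lower number from compound 3 to compound 4 (0.06 log units; within the scatter), a number hardly moved from that of compound 3. Within the data shown here, compound 4 is therefore estimated at 21000 nM in this assay, with a range from 10000 nM to 45000 nM given the single precedent.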

Compound 4, half-maximal inhibitory concentration: 19900 nM
Compound 4: the middle estimate sits 1.1-fold (0.02 log units) above what was measured, within the range that was stated.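

The step on the second core reads a 1.2-fold lower number from compound 3 to compound 4 (0.08 log units; within the scatter) in this assay and so matches the small step seen on the first core. The change from 4-chlorophenyl to 4-bromophenyl carries across the two cores with no readable difference between the steps: the same change on two cores in this assay, a 1.1-fold lower number (0.06 log units; within the scatter) from compound 1 to compound 2 and a 1.2-fold lower number (0.08 log units; within the scatter) from compound 3 to compound 4, 1.1-fold (0.02 log units) apart, within the scatter of two such steps. This shows only that chloro and bromo give numbers within the scatter of each other at this place on these two cores in this one read-out; with just two pairs and both steps within the scatter, it sets no size for the change and gives no rule for any other core.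

Still open, going by these compounds, is whether a group other than chloro or bromo at this place on the six-membered aromatic ring, such as an amine, a carboxylic acid or a longer chain, moves the number at all. Also open is which part of the difference between the two cores goes with the numbers of compound 1 and compound 3; no pair shown separates those parts.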